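Compound 3 to compound 4: a swap on the carbonyl carbon

The source may hold more compounds than are shown below. What is called first, only, known or untested is meant among the compounds shown, and "the series" means these compounds.

Measured values in an ADME assay on SH-SY5Y cells (Homo sapiens) for cytotoxicity, read by MTT assay, with a stated time of 72 h; a lower number here means a stronger inhibitor, a higher number a weaker inhibitor:
- compound 1 `COc1ccc(C(=O)N2CCN(CC(=O)N3CCN(CCCc4c[nH]c5ccccc45)CC3)CC2)cc1` gives 148000 nM
- compound 2 `COc1cccc(C(=O)N2CCN(CC(=O)N3CCN(CCCc4c[nH]c5ccccc45)CC3)CC2)c1` gives > 200000 nM as a limit of the assay
- compound 3 `COc1ccc(C(=O)N2CCN(CC(=O)N3CCN(CCCc4c[nH]c5ccc(F)cc45)CC3)CC2)cc1` gives 161000 nM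

Compound 3 at 161000 nM lies within the scatter of compound 1 at 148000 nM. The only other entry, from compound 2, is a limit. The change to compound 4 `O=C(CN1CCN(C(=O)c2cccc(F)c2)CC1)N1CCN(CCCc2c[nH]c3ccc(F)cc23)CC1` is 3-fluorophenyl in place of 4-methoxyphenyl on a carbonyl carbon and reads 3-fluorophenyl in place of 4-methoxyphenyl on a carbonyl carbon. For the measured compounds named here, two measured steps bear on it. On a carbonyl carbon as well, 3-methoxyphenyl in place of 4-methoxyphenyl gave an at least 1.3-fold higher number from compound 1 to compound 2 (0.13 log units; that floor lies within the scatter) as a floor only. Fluoro in place of hydrogen on an aromatic carbon gave a 1.1-fold higher number from compound 1 to compound 3 (0.04 log units; within the scatter) on an aromatic carbon of the shared core. Neither step is the exact change, but neither goes beyond the scatter, so no step beyond the scatter and no direction is expected in this assay for this swap. The estimated move is a 1.1-fold higher number from compound 3 to compound 4 (0.02 log units; within the scatter) and counts as no real change. Compound 4 may also return only a limit, given the limit of > 200000 nM in this assay, at which 1 of the 3 values shown sits, in this series. For compound 4 the expected value is 170000 nM with an estimated range from 100000 nM to 280000 nM in this cell test.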

Compound 4, half-maximal inhibitory concentration: 169000 nM
Compound 4: middle estimate off by 1.0-fold (0.00 log units), on the high side; the range from low to high includes it.
By their numbers in this assay, from the lowest: compounds 1, 3 and 4 (each within the scatter of the next). At a limit, above all of these: compound 2.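

In this assay the swap on the carbonyl carbon gives a 1.0-fold higher number from compound 3 to compound 4 (0.02 log units; within the scatter). For the compounds shown here, this is the first change of the aryl group at this position that reads as two numbers, since compound 2, changed at the same place, gives > 200000 nM, which is a limit. The 4-methoxyphenyl can thus leave with its oxygen and its hydrogen-bond acceptor, and 3-fluorophenyl can enter, without a step beyond the scatter in this pair.

Going by these compounds, whether an amine or a carboxylic acid on the aryl group at this carbonyl carbon would give a step beyond the scatter stays open. Any such reading would also be bounded at the top of the range: the limit of > 200000 nM in this assay, at which 1 of the 4 values shown sits.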